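Isopropyl carbonate: an expected half-life for compound 3

The source may report more compounds than this note shows. Statements on the series, on what has been measured and on what is new or still open speak of the compounds shown alone.

Compound 1 `CCCCOC(=O)OCC(CO)CCn1cnc2cnc(N)nc21` carries a butyl carbonate on the shared core. In an ADME assay for pharmacokinetics, read by HPLC, at 37 degrees C, at pH 1.2 (a lower number here means that the compound disappears faster, a higher number that the compound lasts longer), compound 1 gives 696 h. Among the measured compounds shown here, its only measured companion is compound 2 `CCCCCOC(=O)OCC(CO)CCn1cnc2cnc(N)nc21`, in which a methyl replaces a hydrogen on a saturated chain carbon, four bonds along the chain from an oxygen next to a carbonyl group; in this assay compound 2 gives 600 h. The step of a 1.2-fold lower number from compound 1 to compound 2 (0.06 log units; within the scatter) lies within the scatter, so the two numbers cannot be told apart, and compound 1 stands alongside compound 2 rather than clearly above it.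

Compound 3 `CC(C)OC(=O)OCC(CO)CCn1cnc2cnc(N)nc21` differs from compound 1 by isopropyl in place of butyl on an oxygen next to a carbonyl group. For the measured compounds named here, the one measured step touches the same chain at the oxygen next to the carbonyl group and changed the half-life by an amount within the scatter. On that basis no step beyond the scatter is expected for compound 3 in this assay, so the estimated step is a 1.1-fold lower number from compound 1 to compound 3 (0.03 log units; within the scatter). The expected half-life of compound 3 is therefore 650 h, within the range 330 h to 1300 h.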

Compound 3, half-life: 2110 h
Beside the measured number, compound 3's estimate is 3.2-fold (0.51 log units) below it; measured number outside the range, above it.
By their numbers in this assay, from the lowest: compounds 2 and 1 (each within the scatter of the next); then compound 3.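

In this assay the group on the oxygen next to a carbonyl group can clearly change how long the compound lasts: isopropyl in place of butyl gives a longer half-life (a 3.0-fold higher number from compound 1 to compound 3 (0.48 log units; beyond the scatter)), and isopropyl in place of pentyl does the same (a 3.5-fold higher number from compound 2 to compound 3 (0.55 log units; beyond the scatter)). Compounds 1 and 2 stood within the scatter of each other, so on their own they gave no sign that this position could respond at all; compound 3 now shows that it can, by a modest amount. No measurement shown gives a reason for this difference.

The compounds shown leave open whether the longer half-life goes with the smaller number of carbons or with the isopropyl group itself, and a straight propyl chain on the same oxygen would help to separate these two readings. They also leave open how the half-life would respond to other groups at this position, such as tert-butyl or a chain ending in an amine.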